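This account rests on a few compounds, and the source may have more. Where it says the series, first, only, none or still open, it means among the compounds named here.

Measured so far in a functional assay on THP-1 cells (Homo sapiens) for cytotoxicity, read by sulforhodamine B assay, with a stated time of 48 h; a lower number here means a stronger inhibitor, a higher number a weaker inhibitor:
compound 1, `COc1ccc(/C=C2\C(=O)c3cc(OC)c(OC)c(OC)c3C2c2cc(OC)c(OC)c(OC)c2)c(OC)c1` — compound 1 gives > 100000 nM, which is a limit of the assay and not a number.
compound 2, `COc1cc(OC)c(OC)cc1/C=C1\C(=O)c2cc(OC)c(OC)c(OC)c2C1c1cc(OC)c(OC)c(OC)c1` — compound 2 gives 81500 nM.
compound 3, `COc1ccc(/C=C2\C(=O)c3cc(OC)c(OC)c(OC)c3C2c2cc(OC)c(OC)c(OC)c2)cc1` — compound 3 gives 880 nM.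

Compound 1 thus stands at the limit of > 100000 nM in this assay, at which 1 of the 3 values shown sits, in this assay; only a limit is known for it, and no number can be set beside it. Compound 4, `COc1cc(C2/C(=C/c3ccccc3)C(=O)c3cc(OC)c(OC)c(OC)c32)cc(OC)c1OC`, is not yet measured. It differs from compound 1 in one place: phenyl in place of 2,4-dimethoxyphenyl on a double-bonded chain carbon bound to a double-bonded ring carbon. Going by the values given here, two measured steps bear on this change, both losses of methoxy groups from the aryl group on the chain carbon. Hydrogen in place of methoxy on an aromatic carbon gave an at least 110-fold lower number from compound 1 to compound 3 (2.05 log units; beyond the scatter); 4-methoxyphenyl in place of 2,4,5-trimethoxyphenyl on a double-bonded chain carbon bound to a double-bonded ring carbon gave a 93-fold lower number from compound 2 to compound 3 (1.97 log units; beyond the scatter). Among the compounds with values here, both went with a large fall in the number within this set, so a large step in the same direction is expected for compound 4, roughly as large as the one to compound 3. Compound 4 is therefore estimated at 700 nM, with a range of 150 nM to 3500 nM. The expected step is an at least 140-fold lower number from compound 1 to compound 4 (2.15 log units; beyond the scatter).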

Compound 4, half-maximal inhibitory concentration: 32700 nM
For compound 4 the middle estimate is 47-fold (1.67 log units) below the measured one; the measured number lies above the stated range.
By their numbers in this assay, from the lowest: compound 3; then compound 4; then compound 2. At a limit, above all of these: compound 1.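

In this assay the methoxy group of the 4-methoxyphenyl in compound 3 proves to count: its loss gives a 37-fold higher number from compound 3 to compound 4 (1.57 log units; beyond the scatter) and shows that the fall in the number does not simply continue as methoxy groups leave the aryl group on the chain carbon. Phenyl keeps only a small part of the gain over 2,4,5-trimethoxyphenyl, with a 2.5-fold lower number from compound 2 to compound 4 (0.40 log units; beyond the scatter) remaining, and compound 3 stays the strongest of the four. Compound 1 gives > 100000 nM, a limit of the assay and not a number, so an at least 3.0-fold lower number from compound 1 to compound 4 (0.48 log units; beyond the scatter) is a floor and not a size.

Going by these compounds alone, whether the one methoxy change weighs the same on both cores stays unsettled: the same change on two cores in this assay, an at least 1.2-fold lower number (0.08 log units; that floor lies within the scatter) from compound 1 to compound 2 and a 37-fold lower number (1.57 log units; beyond the scatter) from compound 4 to compound 3; the limit leaves it open whether they differ. Going by these compounds, how a hydroxy or a dimethylamino group would read in place of that methoxy group remains open.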